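The source may report more compounds than this note shows. Statements on the series, on what has been measured and on what is new or still open speak of the compounds shown alone.

Working notes on the series. The shared core stands in compound 1 `Cc1ncc([N+](=O)[O-])n1CC(O)CSC(=S)N1CCC(Cc2ccccc2)CC1`, which in a toxicity assay on HeLa cells (Homo sapiens) for cytotoxicity, read by MTT assay, with a stated time of 24 h (a higher number here means a weaker inhibitor, a lower number a stronger inhibitor), gives 1320000 nM. Compound 2 `CCN1CCN(C(=S)SCC(O)Cn2cc([N+](=O)[O-])nc2C)CC1` carries a 4-ethylpiperazin-1-yl on the thiocarbonyl carbon. In this assay compound 2 reaches only a limit of the assay, > 5000000 nM, and no number is known for it. Compound 3 `Cc1nc([N+](=O)[O-])cn1CC(O)CSC(=S)N1CCCC(C)C1` in this assay gives 2700000 nM. Going by the values given here, the one measured step that starts from compound 2 is an at least 1.8-fold lower number from compound 2 to compound 3 (0.26 log units; that floor lies within the scatter), and its floor sits within the scatter, so it fixes compound 2 only as the member without a number, as the limit of > 5000000 nM in this assay, at which 1 of the 3 values shown sits, records.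

Compound 4 `Cc1nc([N+](=O)[O-])cn1CC(O)CSC(=S)N1CCN(C(=O)OC(C)(C)C)CC1` differs from compound 2 by tert-butoxycarbonyl in place of ethyl on an amine nitrogen in a ring. Among the compounds with values here, no measured step exchanges an ethyl for a tert-butoxycarbonyl on that ring nitrogen, so the only guide is that compound 1 and compound 3 each gave a number while compound 2 did not. The step expected in this assay is therefore small or none beyond the scatter, and a second limit is a real possibility. For compound 4 the expected result in this assay is 3000000 nM, with a range from 1000000 nM to 10000000 nM. That estimate means an expected step of an at least 1.6-fold lower number from compound 2 to compound 4 (0.22 log units; that floor lies within the scatter).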

Compound 4, half-maximal inhibitory concentration: > 5000000 nM
Compound 4 was reported as a limit; the forecaster's own chance of this, stated with the estimate: 35%; middle value at least 1.6-fold (0.22 log units) from the limit.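

In this assay compound 4 gives > 5000000 nM, a limit of the assay and not a number. Going by these compounds alone, no step from compound 2 to compound 4 can be read, because both compounds stand at the same limit: the limit of > 5000000 nM in this assay, at which 2 of the 4 values shown sit. The compounds shown leave open whether tert-butoxycarbonyl and ethyl on that ring nitrogen differ at all in this assay.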